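The source may report more compounds than this note shows. Statements on the series, on what has been measured and on what is new or still open speak of the compounds shown alone.

In an assay on CHO cells for displacement of a labelled ligand from Alpha-2B adrenergic receptor (Homo sapiens) (on this read-out lower numbers stand for stronger inhibition and higher numbers for weaker inhibition), compound 1 `CC(Oc1ccccc1Br)C1=NCCN1` gives 355 nM, and compound 2 `CC(C)Oc1ccccc1OC(C)C1=NCCN1` gives 1580 nM. For the measured compounds named here, the single measured step, a 4.5-fold higher number from compound 1 to compound 2 (0.65 log units; beyond the scatter), is the only comparison available so far. Compound 2 therefore stands with the higher of the two numbers, its nearest neighbour being compound 1.

Compound 3 `CC(=O)c1ccccc1OC(C)C1=NCCN1` differs from compound 2 by acetyl in place of isopropoxy on an aromatic carbon. Going by the values given here, no measured step exchanges these two groups directly. Among the compounds with values here, the one step recorded, a 4.5-fold higher number from compound 1 to compound 2 (0.65 log units; beyond the scatter), shows that the group on that aromatic carbon can move the number by a modest amount, but it says nothing about acetyl itself, so any forecast rests on weak ground.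

The expected step of a 1.6-fold lower number from compound 2 to compound 3 (0.20 log units; within the scatter) is a small shift, with no confident direction. Compound 3 is accordingly estimated at 1000 nM, with a range of 350 nM to 3000 nM.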

Compound 3, inhibition constant: 6170 nM
Beside the measured number, compound 3's estimate is 6.2-fold (0.79 log units) below it, and the stated range ends below it.
By their numbers in this assay, from the lowest: compound 1; then compound 2; then compound 3.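

In this assay, acetyl on this aromatic carbon, ortho to a group of 8 heavy atoms, gives a 3.9-fold higher number from compound 2 to compound 3 (0.59 log units; beyond the scatter), so isopropoxy is not the upper end of what this position allows. Set against bromo, the same group gives a 17-fold higher number from compound 1 to compound 3 (1.24 log units; beyond the scatter), a large step that shows this single position can span far more than the first pair suggested, with bromo, isopropoxy and acetyl running from the lowest number to the highest. Nothing available accounts for this order.

The compounds shown cover only these three groups at one position, so it remains open where an amine, a carboxylic acid or a longer chain would fall in this order. Going by these compounds, whether the order holds with the rest of the core changed also remains open.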